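Swapping the benzyl substituent in a pyrazole acid series

The source may report more compounds than this note shows. Statements on the series, on what has been measured and on what is new or still open speak of the compounds shown alone.

Of the compounds shown here, two of a shared core have been measured so far. Compound 1 `CC(C)c1c(C(=O)N(C)Cc2ccccc2)nn(-c2ccc(F)cc2)c1OC[C@@H](O)C[C@@H](O)CC(=O)O` carries an unsubstituted benzyl group on the amide nitrogen; in an assay on microsomes from liver for inhibition of 3-hydroxy-3-methylglutaryl-coenzyme A reductase (Rattus norvegicus) (on this read-out lower numbers stand for stronger inhibition and higher numbers for weaker inhibition), compound 1 gives 5.2 nM. Compound 2 `Cc1ccc(CN(C)C(=O)c2nn(-c3ccc(F)cc3)c(OC[C@@H](O)C[C@@H](O)CC(=O)O)c2C(C)C)cc1` differs from it only by a methyl on that benzyl ring, and in this assay compound 2 gives 37 nM. Compound 2 stands at the higher of the two numbers, the step of a 7.1-fold higher number from compound 1 to compound 2 (0.85 log units; beyond the scatter) being beyond the scatter and meaning weaker inhibition.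

Compound 3 `COc1cc(CN(C)C(=O)c2nn(-c3ccc(F)cc3)c(OC[C@@H](O)C[C@@H](O)CC(=O)O)c2C(C)C)cc(OC)c1` changes the same ring once more: 3,5-dimethoxyphenyl in place of 4-methylphenyl on a saturated chain carbon bound to an amide-type nitrogen. Among the compounds with values here, the only measured step that touches this ring is the one from compound 1 to compound 2, where adding a single methyl weakened inhibition modestly. The two methoxy groups in compound 3 sit at different places on the ring, so that step bears on it only loosely; it suggests that decorating this ring does not help, but says nothing firm about two methoxy groups.

For compound 3 the expectation is therefore a step of about a 1.1-fold higher number from compound 2 to compound 3 (0.03 log units; within the scatter), essentially within the scatter, giving an estimated 40 nM with a range from 12 nM to 130 nM.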

Compound 3, half-maximal inhibitory concentration: 43 nM
Compound 3: middle estimate off by 1.1-fold (0.03 log units), on the low side, and the stated range covers the measured number.
By their numbers in this assay, from the lowest: compound 1; then compounds 2 and 3 (each within the scatter of the next).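

In this assay, the change from 4-methylphenyl to 3,5-dimethoxyphenyl on a saturated chain carbon bound to an amide-type nitrogen gives a 1.2-fold higher number from compound 2 to compound 3 (0.07 log units; within the scatter), so this read-out does not separate these two decorated rings, even though the incoming group brings two hydrogen-bond acceptors and the outgoing one brings none. Measured against the plain phenyl ring, the same dimethoxy decoration gives an 8.3-fold higher number from compound 1 to compound 3 (0.92 log units; beyond the scatter), which means that both decorated rings shown so far inhibit more weakly than compound 1, and neither compound goes against this among the three. Nothing available explains why the two decorated rings land so close together or why both fall short of the plain ring.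

Three compounds cannot show whether any addition to this ring weakens inhibition or whether the methyl and the methoxy groups simply happen to cost about the same. Going by these compounds, a ring carrying a single methoxy group, a hydroxyl group or an amine would test how general the loss is, and whether any group can match the undecorated phenyl ring of compound 1 remains open.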